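Series notes: removing a methyl from the benzimidazole partner of compound 2

A few compounds are considered here, and "the series" means these few. Any claim that something is new, unique, unknown or untested is made for them only; others in the source may bear on it.

The parent of this pair is compound 1 `COc1ccc2[nH]c(=O)c(-c3nc4cc(C)c(C)cc4[nH]3)cc2c1`. In a functional assay on SK-OV-3 cells (Homo sapiens) for cytotoxicity, read by MTT assay, with a stated time of 48 h (on this read-out higher numbers stand for weaker inhibition and lower numbers for stronger inhibition), compound 1 gives only a limit, > 100000 nM. Its methyl counterpart is compound 2 `Cc1ccc2[nH]c(=O)c(-c3nc4cc(C)c(C)cc4[nH]3)cc2c1`. In this assay compound 2 likewise gives only a limit, > 100000 nM. The step that the two limits leave unreadable from compound 1 to compound 2 therefore cannot be sized, a situation summed up by the limit of > 100000 nM in this assay, at which 2 of the 2 values shown sit. Where compound 2 stands, then, is at the limit of this assay, with no number to anchor it.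

The next compound is compound 3 `Cc1cc2nc(-c3cc4ccccc4[nH]c3=O)[nH]c2cc1C`, which differs from compound 2 by hydrogen in place of methyl on an aromatic carbon. Among the compounds with values here, no measured step bears on this change; the only step in hand, from methoxy to methyl, is itself unreadable. With both measured values at the limit, the expectation for compound 3 is that the step of a number no higher from compound 2 to compound 3 (the limit leaves the size open) stays within scatter of that limit. The estimated value of compound 3 in this assay is 100000 nM, in the range 30000 nM to 300000 nM.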

Compound 3, half-maximal inhibitory concentration: > 100000 nM
Compound 3 gave a limit, no number; the forecaster's own chance of this, stated with the estimate: 80%; the middle value sits exactly at the limit.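

Within the data shown here, no step among compound 1, compound 2 and compound 3 can be read, since all three give only a limit in this assay. The compounds shown leave open whether any change on the shared core would give a readable value.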